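A few compounds are considered here, and "the series" means these few. Any claim that something is new, unique, unknown or untested is made for them only; others in the source may bear on it.

Three compounds have been measured in a functional assay on SF-539 cells (Homo sapiens) for inhibition, read by sulforhodamine B assay, with a stated time of 48 h; a higher number here means a weaker inhibitor of growth, a lower number a stronger inhibitor of growth:

Compound 1, `COc1cc(-c2nn(-c3cccc(NC(=O)c4ccc(Cl)c(C(F)(F)F)c4)c3)cc2-c2ccncc2)ccc1Cl`: 20300 nM
Compound 2, `COc1cc(-c2nn(-c3cccc(NC(=O)Nc4ccc(Cl)c(C(F)(F)F)c4)c3)cc2-c2ccncc2)ccc1Cl`: 6340 nM
Compound 3, `COc1cc(-c2nn(-c3cccc(NC(=O)c4ccccc4)c3)cc2-c2ccncc2)ccc1Cl`: 2880 nM

Among these three numbers compound 2 stands second highest. Its nearest neighbour is compound 3, reached by a 2.2-fold lower number from compound 2 to compound 3 (0.34 log units; beyond the scatter); its furthest is compound 1, from which it is separated by a 3.2-fold lower number from compound 1 to compound 2 (0.51 log units; beyond the scatter). Compound 4, `O=C(Nc1cccc(-n2cc(-c3ccncc3)c(-c3ccc(Cl)c(O)c3)n2)c1)Nc1ccc(Cl)c(C(F)(F)F)c1`, differs from compound 2 in one place: hydrogen in place of methyl on an oxygen on an aromatic ring.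

The measured steps all concern the group on the carbonyl carbon: a 3.2-fold lower number from compound 1 to compound 2 (0.51 log units; beyond the scatter), a 7.0-fold lower number from compound 1 to compound 3 (0.85 log units; beyond the scatter) and a 2.2-fold lower number from compound 2 to compound 3 (0.34 log units; beyond the scatter). Going by the values given here, none of them touches the oxygen on the aromatic ring, so no measured step bears on the change from compound 2 to compound 4, and the expectation rests on compound 2 alone. Compound 4 is therefore expected to show a step of a 1.0-fold lower number from compound 2 to compound 4 (0.00 log units; within the scatter), which is not beyond the scatter in either direction. The estimate for compound 4 in this assay is 6300 nM, with a range from 2000 nM to 20000 nM.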

Compound 4, concentration for total growth inhibition: 2390 nM
Beside the measured number, compound 4's estimate is 2.6-fold (0.42 log units) above it; the range from low to high includes it.
By their numbers in this assay, from the lowest: compounds 4 and 3 (each within the scatter of the next); then compound 2; then compound 1.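

In this assay, the group on the aromatic oxygen proves able to move the number: hydrogen in place of methyl, which turns methoxy into hydroxy, gives a 2.7-fold lower number from compound 2 to compound 4 (0.42 log units; beyond the scatter). Going by these compounds alone, the earlier compounds varied only the group on the carbonyl carbon, so this is the first sign that the 4-chloro-3-methoxyphenyl side also matters, and here losing the methyl yields a stronger inhibitor of growth. Nothing shown accounts for this step.

As far as these compounds go, whether methoxy to hydroxy acts the same way with the other carbonyl groups, those of compound 1 and compound 3, remains open, since the change is seen only against compound 2. Also open, from the compounds shown here alone, is how an ethoxy group, an amine or a fluorine atom in place of the hydroxy would behave.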